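The source may report more compounds than this note shows. Statements on the series, on what has been measured and on what is new or still open speak of the compounds shown alone.

Working notes on the series. Compound 1 `Cc1ccc(S(=O)(=O)Oc2ccc3c(c2C)[C@H](Cn2cc(-c4ccc(C(F)(F)F)cc4)nn2)[C@@]24CC(=O)[C@@](C)(CC[C@@H]32)C4)cc1` carries a (4-methylphenyl)sulfonyl on an oxygen of the shared core. In a functional assay on MCF7 cells (Homo sapiens) for cytotoxicity, read by MTT assay, with a stated time of 4 days (on this read-out higher numbers stand for weaker inhibition and lower numbers for stronger inhibition), compound 1 gives only a limit of the assay, > 20000 nM. Compound 2 `Cc1c(O)ccc2c1[C@H](Cn1cc(-c3ccc(C(F)(F)F)cc3)nn1)[C@@]13CC(=O)[C@@](C)(CC[C@@H]21)C3` has hydrogen in place of (4-methylphenyl)sulfonyl on an oxygen on an aromatic ring. In this assay compound 2 likewise returns only a limit, > 20000 nM. Among the measured compounds shown here, the single measured step, a step that the two limits leave unreadable from compound 1 to compound 2, therefore cannot be sized, and the whole record reduces to the limit of > 20000 nM in this assay, at which 2 of the 2 values shown sit. Compound 1 thus stands at the assay limit and nowhere more precise.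

Compound 3 `COc1ccc(-c2cn(C[C@H]3c4c(ccc(OS(=O)(=O)c5ccc(C)cc5)c4C)[C@@H]4CC[C@@]5(C)C[C@]43CC5=O)nn2)cc1` differs from compound 1 by methoxy in place of trifluoromethyl on an aromatic carbon. For the measured compounds named here, no measured step touches this aromatic carbon; the one recorded step concerns the oxygen on the aromatic ring and was itself unreadable. The measured compounds thus give no guide to the size or direction of the change in this assay. Compound 3 is expected to remain at or near the limit, with the step that the limit leaves unreadable from compound 1 to compound 3 as a nominal placeholder. The estimate for compound 3 in this assay is 30000 nM, with a range from 8000 nM to 120000 nM, and a limit rather than a number is the likelier report.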

Compound 3, half-maximal inhibitory concentration: > 20000 nM
Compound 3: only a limit was reported; the forecaster's own chance of this, stated with the estimate: 75%; the middle value does not contradict the limit.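

In this assay compound 3 gives > 20000 nM, a limit of the assay and not a number. The step between compound 1 and compound 3 cannot be read, because both stop at a limit: the limit of > 20000 nM in this assay, at which 3 of the 3 values shown sit. The compounds shown leave open whether exchanging trifluoromethyl for methoxy changes the read-out at all.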